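The compounds below may be only part of what the source reports. "The series", "measured", "known", "first", "only" and "open" are said of these compounds alone.

Compound 1 `CCOC(=O)CN(C(=O)/C(C)=C/c1ccc(C(=O)Oc2ccc(C(=N)N)cc2)cc1)C1CCCCC1` — > 1 h
Compound 2 `C=CCN(CCCC(=O)OCC)C(=O)/C(C)=C/c1ccc(C(=O)Oc2ccc(C(=N)N)cc2)cc1` — 1 h
Compound 3 `CCOC(=O)CN(Cc1ccccc1)C(=O)/C(C)=C/c1ccc(C(=O)Oc2ccc(C(=N)N)cc2)cc1` — 0.733 h

Three compounds sharing one core were run in an in vitro ADME assay on the whole organism (small intestine) for pharmacokinetics, with Rattus norvegicus as the target; a higher number here means that the compound lasts longer, a lower number that the compound disappears faster. For compound 1 the result is a limit of the assay and not a number, (the limit of > 1 h in this assay, at which 1 of the 3 values shown sits). Compound 2 and compound 3 gave numbers that lie within the usual scatter of one another, so neither can be placed ahead of the other. Within the data shown here, the only single-change step among the measured compounds is an at least 1.3-fold lower number from compound 1 to compound 3 (0.13 log units; that floor lies within the scatter), and its floor lies within the scatter.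

Compound 4 `C=CCN(CCC(=O)OCC)C(=O)/C(C)=C/c1ccc(C(=O)Oc2ccc(C(=N)N)cc2)cc1` differs from compound 2 by ethoxycarbonyl in place of (ethoxycarbonyl)methyl on a saturated chain carbon, two bonds along the chain from an amide-type nitrogen. Among the measured compounds shown here, no measured step shortens this chain, so the measured steps offer nothing that bears directly on it; the one step that is known, benzyl in place of cyclohexyl, already sits within the scatter. The step of no change at the digits printed from compound 2 to compound 4 (within the scatter) is therefore expected to stay within the scatter, with no direction favoured. Compound 4 is estimated at 1 h, between 0.5 h and 2 h, in this assay.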

Compound 4, half-life: 1 h
Beside the measured number, compound 4's estimate shows no gap at the digits printed; measured number inside the range.
By their numbers in this assay, from the lowest: compounds 3, 2 and 4 (each within the scatter of the next).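

Shortening the chain from 3-(ethoxycarbonyl)propyl to 2-(ethoxycarbonyl)ethyl gives no change at the digits printed from compound 2 to compound 4 (within the scatter) in this assay. Among these compounds, this is the first measured change at this position, since the only earlier step swapped cyclohexyl for benzyl on the amide-type nitrogen, and for this pair the half-life does not respond to the change in chain length. The result for compound 1 is a limit of the assay and not a number: the limit of > 1 h in this assay, at which 1 of the 4 values shown sits.

On these data alone, compound 2 and compound 4 print the same figure as that limit, so it remains open whether this reading could register a difference between them. Also open, as far as these compounds go, is whether a longer chain, or a carboxylic acid in place of the ethyl ester, would leave the half-life within the scatter.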